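Ring contraction of the ether amine in compound 3

The compounds below may be only part of what the source reports. "The series", "measured", "known", "first", "only" and "open" are said of these compounds alone.

Compound 3, `Cc1cc(Cl)cc(-c2ccnc3cc(CN4C(=O)CCC4=O)sc23)c1OC1CCNCC1`, has the highest number of the three measured compounds in an assay on isolated protein for inhibition of ubiquitin carboxyl-terminal hydrolase 7 (Homo sapiens), read by fluorescence, with stated times of 30 min and 1 h (a lower number here means a stronger inhibitor, a higher number a weaker inhibitor), at 8 nM. Compound 1, `Cc1cc(Cl)cc(-c2ccnc3cc(CN4C(=O)CCC4=O)sc23)c1O[C@@H]1CCNC[C@@H]1C`, gives 2.1 nM, and compound 2, `Cc1cc(Cl)cc(-c2ccnc3cc(CN4C(=O)CCC4=O)sc23)c1CN1CCNC[C@@H]1C`, gives 6.6 nM. The measured steps are a 3.8-fold higher number from compound 1 to compound 3 (0.58 log units; beyond the scatter), a 3.1-fold higher number from compound 1 to compound 2 (0.50 log units; beyond the scatter) and a 1.2-fold higher number from compound 2 to compound 3 (0.08 log units; within the scatter); so removing the methyl from the saturated ring and exchanging the whole side chain each cost something, while the last pair sits within the scatter.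

Compound 4, `Cc1cc(Cl)cc(-c2ccnc3cc(CN4C(=O)CCC4=O)sc23)c1O[C@H]1C[C@H](N)C1`, differs from compound 3 by 3-aminocyclobutyl in place of piperidin-4-yl on an oxygen on an aromatic ring. For the measured compounds named here, no measured step covers this exchange directly. The nearest comparison, a 1.2-fold higher number from compound 2 to compound 3 (0.08 log units; within the scatter), shows that two different amine-bearing side chains on the aromatic carbon give numbers within the scatter of each other, and a 3.8-fold higher number from compound 1 to compound 3 (0.58 log units; beyond the scatter) shows that a small alteration on the saturated ring can move the number modestly. A four-membered ring with the amine on it has no precedent among these compounds, so the estimate is uncertain. Compound 4 is expected to show a 2.5-fold higher number from compound 3 to compound 4 (0.40 log units; beyond the scatter), a modest weakening. The estimate for compound 4 is 20 nM, with a range from 6 nM to 70 nM.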

Compound 4, half-maximal inhibitory concentration: 3.4 nM
The estimate for compound 4 lay 5.9-fold (0.77 log units) above the measured number; the whole stated range lies above it.
By their numbers in this assay, from the lowest: compounds 1, 4, 2 and 3 (each within the scatter of the next, the first and the last beyond it).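

In this assay, for the compounds shown here, the step from piperidin-4-yl to 3-aminocyclobutyl on the oxygen gives a 2.4-fold lower number from compound 3 to compound 4 (0.37 log units; beyond the scatter) and so shows that this position accepts a four-membered ring of carbon only, with the amine no longer a ring member. Going by these compounds alone, the earlier compounds carried only six-membered rings containing nitrogen here, and among them the one step beyond the scatter on the ether side was the one that removed the ring methyl of compound 1. Compound 4 has no such methyl, yet the reading a 1.6-fold higher number from compound 1 to compound 4 (0.21 log units; within the scatter) places it within the scatter of compound 1 and the reading a 1.9-fold lower number from compound 2 to compound 4 (0.29 log units; within the scatter) places it within the scatter of compound 2 as well, so the methylpiperidine is not the only ether amine that reaches this range of numbers.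

Nothing in the data on hand accounts for the difference between the two rings. Still open, as far as these compounds go, are whether a methyl on the amine of the 3-aminocyclobutyl group or an azetidine ring in place of the cyclobutane would keep the number in this range, and whether the other arrangement of the two stereocentres would read the same.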